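Sulfonyl aryl variation on the shared core: compound 4

The source may hold more compounds than are shown below. What is called first, only, known or untested is meant among the compounds shown, and "the series" means these compounds.

Measured compounds, values from a functional assay on K562 cells (Homo sapiens) for inhibition, read by trypan blue exclusion, with a stated time of 72 h; on this read-out higher numbers stand for weaker inhibition and lower numbers for stronger inhibition:
- compound 1 `Cn1c(=O)c(S(=O)(=O)c2ccc(F)cc2[N+](=O)[O-])cc2cnc(Nc3ccc4[nH]ccc4c3)nc21`: 900 nM
- compound 2 `Cn1c(=O)c(S(=O)(=O)c2ccc(Cl)cc2)cc2cnc(Nc3ccc4[nH]ccc4c3)nc21`: 100 nM
- compound 3 `Cn1c(=O)c(S(=O)(=O)c2ccc(O)cc2)cc2cnc(Nc3ccc4[nH]ccc4c3)nc21`: 100 nM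

Compound 3 stands level with compound 2 at the digits shown, the two together giving the lowest numbers of the three; the step of no change at the digits printed from compound 2 to compound 3 (within the scatter) lies within the scatter. Compound 1 sits well apart, as the step of a 9.0-fold lower number from compound 1 to compound 3 (0.95 log units; beyond the scatter) shows.

Compound 4 `COc1ccc(S(=O)(=O)c2cc3cnc(Nc4ccc5[nH]ccc5c4)nc3n(C)c2=O)cc1` differs from compound 3 by methyl in place of hydrogen on an oxygen on an aromatic ring, that is hydroxy to methoxy, (4-hydroxyphenyl)sulfonyl to (4-methoxyphenyl)sulfonyl.

The step that bears most directly on this is no change at the digits printed from compound 2 to compound 3 (within the scatter), where the group at this same position was swapped with no change beyond the scatter. The larger steps of a 9.0-fold lower number from compound 1 to compound 2 (0.95 log units; beyond the scatter) and a 9.0-fold lower number from compound 1 to compound 3 (0.95 log units; beyond the scatter) concern the whole aryl ring on the sulfonyl sulfur and do not separate the two single-substituent variants. On that basis the step of a 1.1-fold higher number from compound 3 to compound 4 (0.04 log units; within the scatter) is expected to fall within the scatter. Compound 4 is therefore estimated at 110 nM in this assay, with a range of 50 nM to 250 nM.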

Compound 4, half-maximal inhibitory concentration: 300 nM
The estimate for compound 4 lay 2.7-fold (0.44 log units) below the measured number, and the stated range ends below it.
By their numbers in this assay, from the lowest: compounds 2 and 3 (each within the scatter of the next); then compound 4; then compound 1.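

In this assay this position proves sensitive to the change: capping the hydroxy as methoxy gives a step beyond the scatter (a 3.0-fold higher number from compound 3 to compound 4 (0.48 log units; beyond the scatter)), which the swap of chloro for hydroxy at the same place did not show. Methoxy also parts from chloro (a 3.0-fold higher number from compound 2 to compound 4 (0.48 log units; beyond the scatter)), so the two earlier substituents do not mark out a flat stretch that takes any small group, though the 4-methoxyphenyl group still keeps an edge over the 4-fluoro-2-nitrophenyl group (a 3.0-fold lower number from compound 1 to compound 4 (0.48 log units; beyond the scatter)). No measurement at hand speaks to the cause of the methoxy step.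

Open, on these data alone, is whether a longer chain on this oxygen, such as ethoxy, moves the number further than methoxy. Also open, as far as these compounds go, is whether an amine or a carboxylic acid at this place reads with compound 3 or with compound 4.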